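Cyclohexyl Replacing Difluorocyclohexyl in a Calcium Flux Agonist Series

The source may hold more compounds than are shown below. What is called first, only, known or untested is meant among the compounds shown, and "the series" means these compounds.

Compound 1, `CN(C[C@H]1Cc2c(cccc2N2CCN3CCC[C@H]3C2)CN1)[C@H]1CCCc2cccnc21`: in a functional assay on CCRF-CEM cells for agonist activity at C-X-C chemokine receptor type 4 (Homo sapiens), read by calcium flux, with a stated time of 25 min (a higher number here means that more compound is needed for the effect, a lower number that less compound is needed), compound 1 gives > 30000 nM, a limit of the assay rather than a number.
Compound 2, `FC1(F)CCC(CN(C[C@H]2Cc3c(cccc3N3CCNCC3)CN2)[C@H]2CCCc3cccnc32)CC1`: in this assay compound 2 gives > 30000 nM, again only a limit.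
Compound 3, `CN(C[C@H]1Cc2c(cccc2N2CCN(c3ncccn3)CC2)CN1)[C@H]1CCCc2cccnc21`: in this assay compound 3 gives > 30000 nM, also a limit.

Compound 2 therefore stands at the limit of > 30000 nM in this assay, at which 3 of the 3 values shown sit; nothing separates it from the others on the numbers shown. Compound 4, `c1cnc2c(c1)CCC[C@@H]2N(CC1CCCCC1)C[C@H]1Cc2c(cccc2N2CCNCC2)CN1`, differs from compound 2 by cyclohexyl in place of 4,4-difluorocyclohexyl on a saturated chain carbon bound to an amine nitrogen. For the measured compounds named here, no pair of measured compounds differing in one place is available, so this step has no measured precedent. The step that the limit leaves unreadable from compound 2 to compound 4 is expected to be none beyond the scatter. Compound 4 is accordingly estimated at 40000 nM, with a range from 10000 nM to 200000 nM, and most likely reported again only as a limit.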

Compound 4, half-maximal effective concentration: > 30000 nM
Compound 4 was reported as a limit (the forecaster's own chance of this, stated with the estimate: 85%); the middle value lies beyond the limit too.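

Compound 2 and compound 4 are both reported only as a limit, so no step between them can be read: the limit of > 30000 nM in this assay, at which 4 of the 4 values shown sit.

The compounds shown leave open what concentration, if any, would produce the effect in this assay, and whether cyclohexyl and 4,4-difluorocyclohexyl differ there.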